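Dropping the Chloro from the Benzyl Ester of Compound 3

This account rests on a few compounds, and the source may have more. Where it says the series, first, only, none or still open, it means among the compounds named here.

compound 1 `NCc1ccc(C(=O)OCCc2ccccc2)cc1` 600000000 nM
compound 2 `CCCOC(=O)c1ccc(CN)cc1` 500000000 nM
compound 3 `NCc1ccc(C(=O)OCc2ccc(Cl)cc2)cc1` 30000000 nM

In an assay on isolated protein for inhibition of serine protease 1 (Homo sapiens) (a higher number here means a weaker inhibitor, a lower number a stronger inhibitor), compound 3 holds the lowest of the three numbers; compound 2 stands at 500000000 nM and compound 1 at 600000000 nM, both beyond the scatter from compound 3. Compound 4 `NCc1ccc(C(=O)OCc2ccccc2)cc1` differs from compound 3 by hydrogen in place of chloro on an aromatic carbon. For the measured compounds named here, no measured step removes a chloro; the only single-change step on record, a 1.2-fold lower number from compound 1 to compound 2 (0.08 log units; within the scatter), concerns a different part of the molecule and lies within the scatter, so it offers no guide to this change. The expectation therefore rests on compound 3 alone, and a modest move toward a higher number is expected, a 2.0-fold higher number from compound 3 to compound 4 (0.30 log units; within the scatter). Compound 4 is estimated to give 60000000 nM, with a range from 20000000 nM to 200000000 nM.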

Compound 4, inhibition constant: 30000000 nM
The estimate for compound 4 lay 2.0-fold (0.30 log units) above the measured number, and the stated range covers the measured number.
By their numbers in this assay, from the lowest: compounds 3 and 4 (each within the scatter of the next); then compounds 2 and 1 (each within the scatter of the next).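

Hydrogen in place of chloro on this aromatic carbon gives no change at the digits printed from compound 3 to compound 4 (within the scatter) in this assay, so the chloro is not required for a number at this level. The large step lies elsewhere: phenyl in place of ethyl on the saturated chain carbon bound to the oxygen next to the carbonyl group gives a 17-fold lower number from compound 2 to compound 4 (1.22 log units; beyond the scatter). Nothing on record explains either step.

Going by these compounds, whether a fluoro, a methoxy or a trifluoromethyl group on the same aromatic carbon would also leave the number unmoved remains open. So does whether a second substituent on that ring would shift it.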